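Bromo for chloro on the core of compound 1

This account rests on a few compounds, and the source may have more. Where it says the series, first, only, none or still open, it means among the compounds named here.

Compound 1 `Cc1ccc(CN2C(=O)/C(=N\NC(=S)Nc3ccc(Cl)cc3)c3cc(Cl)ccc32)cc1` gives 9800 nM in a functional assay on L1210 cells (Mus musculus), with a stated time of 48 h (a higher number here means a weaker inhibitor, a lower number a stronger inhibitor), the lowest of the three numbers in hand. Compound 2 `O=C1/C(=N\NC(=S)Nc2ccc(Cl)cc2)c2cc(Cl)ccc2N1Cc1ccc(Cl)cc1` gives 124000 nM and compound 3 `O=C1/C(=N\NC(=S)Nc2ccc(Cl)cc2)c2cc(Cl)ccc2N1Cc1ccc(F)cc1` gives 103000 nM; the step of a 13-fold higher number from compound 1 to compound 2 (1.10 log units; beyond the scatter) and the step of an 11-fold higher number from compound 1 to compound 3 (1.02 log units; beyond the scatter) are both large, whereas a 1.2-fold lower number from compound 2 to compound 3 (0.08 log units; within the scatter) stays within the scatter. Compound 4 `Cc1ccc(CN2C(=O)/C(=N\NC(=S)Nc3ccc(Cl)cc3)c3cc(Br)ccc32)cc1` differs from compound 1 by bromo in place of chloro on an aromatic carbon. Among the compounds with values here, none of the measured steps touches this halogen: all three alter the methyl of compound 1 or what replaces it, so the data give no direct guide. An exchange of one halogen for another at this position is expected to give a step of no change at the digits printed from compound 1 to compound 4 (within the scatter) no larger than the scatter, in either direction. Compound 4 is estimated at 9800 nM, within 4000 nM to 25000 nM.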

Compound 4, half-maximal inhibitory concentration: 193000 nM
Beside the measured number, compound 4's estimate is 20-fold (1.29 log units) below it; measured number outside the range, above it.
By their numbers in this assay, from the lowest: compound 1; then compounds 3, 2 and 4 (each within the scatter of the next).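

The halogen on the core is not a silent position: in this assay, bromo in place of chloro on this aromatic carbon gives a 20-fold higher number from compound 1 to compound 4 (1.29 log units; beyond the scatter) and that step is large. The series therefore responds to a single-atom exchange here as well as at the methyl of compound 1, with every such step from compound 1 going to a higher number. Nothing at hand accounts for this step. Open, going by these compounds, is whether fluoro, methoxy or an amine on this carbon keeps the number of compound 1 or also raises it. Also open, on these data alone, is how bromo here combines with chloro or fluoro in place of the methyl.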